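Swapping the group on the amide nitrogen of compound 3

The compounds below may be only part of what the source reports. "The series", "measured", "known", "first", "only" and "open" are said of these compounds alone.

Compound 1 `COc1cc2nc([S+]([O-])CC(=O)Nc3ccc(C(F)(F)F)cc3)nc(Nc3c(C)cc(/C=C/C#N)cc3C)c2cc1OC` gives 52200 nM in an ADME assay on MT4 cells (Homo sapiens) for cytotoxicity, read by MTT assay, with a stated time of 5 days (on this read-out lower numbers stand for higher toxicity in this test and higher numbers for lower toxicity in this test), while compound 2 `COc1cc2nc([S+]([O-])CC(=O)Nc3cccc(C(F)(F)F)c3)nc(Nc3c(Cl)cc(/C=C/C#N)cc3Cl)c2cc1OC` gives 21800 nM and compound 3 `COc1cc2nc([S+]([O-])CC(=O)Nc3ccc(C(F)(F)F)cc3)nc(Nc3c(Cl)cc(/C=C/C#N)cc3Cl)c2cc1OC` gives 22000 nM there. Compound 3 thus matches compound 2 within the scatter and lies below compound 1. Compound 4 `COc1cc2nc([S+]([O-])CC(=O)Nc3c(C)cc(C)cc3C)nc(Nc3c(Cl)cc(/C=C/C#N)cc3Cl)c2cc1OC` differs from compound 3 in one place: 2,4,6-trimethylphenyl in place of 4-(trifluoromethyl)phenyl on an amide-type nitrogen. The closest measured change, 4-(trifluoromethyl)phenyl in place of 3-(trifluoromethyl)phenyl on that nitrogen, is a 1.0-fold higher number from compound 2 to compound 3 (0.00 log units; within the scatter) and stays within the scatter. The step of a 2.4-fold lower number from compound 1 to compound 3 (0.38 log units; beyond the scatter) is modest and sits elsewhere, on a nitrogen on an aromatic ring. Going by the values given here, no measured compound carries 2,4,6-trimethylphenyl, so the guidance is thin. With the step of a 1.0-fold higher number from compound 2 to compound 3 (0.00 log units; within the scatter) as the guide, no step beyond the scatter is expected in this assay for this swap. The estimated step is a 1.1-fold higher number from compound 3 to compound 4 (0.06 log units; within the scatter) and remains uncertain. The estimate for compound 4 is 25000 nM and the value is expected to fall between 10000 nM and 60000 nM.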

Compound 4, half-maximal cytotoxic concentration: 8870 nM
Estimate against measurement, compound 4: 2.8-fold (0.45 log units) above; measured number below the stated range.
By their numbers in this assay, from the lowest: compound 4; then compounds 2 and 3 (each within the scatter of the next); then compound 1.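

In this assay the group on the amide-type nitrogen proves able to move the number: 2,4,6-trimethylphenyl gives a 2.5-fold lower number from compound 3 to compound 4 (0.39 log units; beyond the scatter) when it replaces 4-(trifluoromethyl)phenyl and a 2.5-fold lower number from compound 2 to compound 4 (0.39 log units; beyond the scatter) when it replaces 3-(trifluoromethyl)phenyl, both toward higher toxicity in this test. Going by these compounds alone, the earlier step at this nitrogen, a 1.0-fold higher number from compound 2 to compound 3 (0.00 log units; within the scatter), compared only two trifluoromethyl-bearing phenyl groups and stayed within the scatter, so it did not show this sensitivity. Nothing available here explains the shift.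

A plain phenyl or a 4-methylphenyl on this nitrogen would help show which part of 2,4,6-trimethylphenyl goes with the step. A phenyl carrying an amine or a carboxylic acid would show how far the number can move in either direction at this position.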